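A few compounds are considered here, and "the series" means these few. Any claim that something is new, unique, unknown or untested is made for them only; others in the source may bear on it.

Compound 3 `c1ccc(-c2ccoc2)c(OCC2=NCCN2)c1` is the only one of the three measured compounds with an actual number in a functional assay for activation of Alpha-1D adrenergic receptor (Homo sapiens), read by calcium flux (a higher number here means that more compound is needed for the effect, a lower number that less compound is needed), where compound 3 gives 5.01 nM. For compound 1 `c1ccc(-c2ccncc2)c(OCC2=NCCN2)c1` this assay returns only a limit, < 100000 nM. For compound 2 `c1coc(-c2ccccc2OCC2=NCCN2)c1` this assay likewise returns only a limit, < 100000 nM. The steps into compound 3, a step that the limit leaves unreadable from compound 1 to compound 3 and a step that the limit leaves unreadable from compound 2 to compound 3, as well as the step that the two limits leave unreadable from compound 1 to compound 2, stay unreadable because of the limit of < 100000 nM in this assay, at which 2 of the 3 values shown sit. Compound 4 `Cc1ccc(-c2ccccc2OCC2=NCCN2)s1` arises by 5-methylthiophen-2-yl in place of furan-3-yl on an aromatic carbon. Among the compounds with values here, no measured step gives a readable size for an exchange of this kind, so the direction for compound 4 is open. In this assay compound 4 is expected at 30 nM, between 3 nM and 500 nM. That estimate means an expected step of a 6.0-fold higher number from compound 3 to compound 4 (0.78 log units; beyond the scatter).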

Compound 4, half-maximal effective concentration: < 100000 nM
Compound 4 ended at the assay's limit (the forecaster's own chance of this, stated with the estimate: 15%); the middle value lies beyond the limit too.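

The steps from compound 1, compound 2 and compound 3 to compound 4 cannot be read in this assay, because of this: the limit of < 100000 nM in this assay, at which 3 of the 4 values shown sit. The compounds shown leave open how large any difference between compound 3 and the other three compounds is.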